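Nitro for Fluoro at the Meta Position of a Chalcone Series

The source may report more compounds than this note shows. Statements on the series, on what has been measured and on what is new or still open speak of the compounds shown alone.

Compound 1 `CC1=C(/C=C/C(=O)/C=C/c2ccccc2F)C(C)(C)CCC1O`: 2900 nM
Compound 2 `CC1=C(/C=C/C(=O)/C=C/c2cccc(F)c2)C(C)(C)CCC1O`: 4400 nM
Compound 3 `CC1=C(/C=C/C(=O)/C=C/c2cc(F)cc(C(F)(F)F)c2)C(C)(C)CCC1O`: 1100 nM

In a functional assay on LNCaP cells (Homo sapiens) for cytotoxicity, read by MTT assay, with a stated time of 72 h (on this read-out higher numbers stand for weaker inhibition and lower numbers for stronger inhibition), compound 2 gives 4400 nM, the highest of the three numbers measured. Its nearest neighbour is compound 1, with a step of a 1.5-fold higher number from compound 1 to compound 2 (0.18 log units; within the scatter) that lies within the scatter, so no order can be drawn between the two. Its furthest neighbour is compound 3, with a step of a 4.0-fold lower number from compound 2 to compound 3 (0.60 log units; beyond the scatter), a modest change beyond the scatter.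

Compound 4 `CC1=C(/C=C/C(=O)/C=C/c2cccc([N+](=O)[O-])c2)C(C)(C)CCC1O` differs from compound 2 by nitro in place of fluoro on an aromatic carbon. Among the measured steps, only the change from compound 2 to compound 3, which also alters the same aromatic ring, bears on this; the swap of fluorine position from compound 1 to compound 2 gave nothing beyond the scatter. Among the measured compounds shown here, neither step exchanges a fluoro for a nitro group, so the data give no direct precedent. For the measured compounds named here, on the single available precedent a modest lowering of the number for compound 4 is expected, though a result within the scatter would not surprise.

Compound 4 is therefore estimated at 2500 nM, within a range from 900 nM to 7000 nM, corresponding to an expected step of a 1.8-fold lower number from compound 2 to compound 4 (0.25 log units; within the scatter).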

Compound 4, half-maximal inhibitory concentration: 2000 nM
Compound 4: the middle estimate sits 1.3-fold (0.10 log units) above what was measured; measured number inside the range.
By their numbers in this assay, from the lowest: compounds 3, 4, 1 and 2 (each within the scatter of the next, the first and the last beyond it).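

In this assay, the carbon that carries fluoro in compound 2 proves responsive to a change of group: nitro in place of fluoro gives a 2.2-fold lower number from compound 2 to compound 4 (0.34 log units; beyond the scatter), whereas moving the fluorine gave only a 1.5-fold higher number from compound 1 to compound 2 (0.18 log units; within the scatter). The earlier gain, a 4.0-fold lower number from compound 2 to compound 3 (0.60 log units; beyond the scatter), came from adding trifluoromethyl at another ring carbon while fluoro stayed in place, so compound 4 is the first compound shown in which the group on this carbon, meta to a large group, is itself exchanged, and the step is modest in size. No measurement to hand accounts for this step, so the data record that the number moved but not why.

From the compounds shown here alone, the exchange adds heavy atoms and hydrogen-bond acceptors together, and this single pair cannot separate the two, so it remains open how an amine, a nitrile or a carboxylic acid on this carbon would compare with fluoro. Going by these compounds, it is also open whether nitro on the carbon that carries fluoro in compound 1 would give a step of similar size.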